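From methoxycarbonyl to fluoro on a shared core

This account rests on a few compounds, and the source may have more. Where it says the series, first, only, none or still open, it means among the compounds named here.

Measured in a functional assay on KYSE-450 cells (Homo sapiens) for inhibition, read by MTT assay, with a stated time of 48 h; on this read-out lower numbers stand for stronger inhibition and higher numbers for weaker inhibition:
compound 1 `COc1ccc(CNc2cc(OC)c(OC)c(OC)c2)cc1[N+](=O)[O-]`: 16800 nM
compound 2 `COc1ccc(CNc2cc(OC)c(OC)c(OC)c2)cc1Br`: 39800 nM
compound 3 `COC(=O)c1cc(CNc2cc(OC)c(OC)c(OC)c2)ccc1OC`: 41100 nM

The three compounds share one core and differ only in a single group on an aromatic carbon. Compound 3 stands level with the bromo analogue, as the data show a 1.0-fold higher number from compound 2 to compound 3 (0.01 log units; within the scatter). The nitro group is what stands apart, with a 2.4-fold higher number from compound 1 to compound 3 (0.39 log units; beyond the scatter) and a 2.4-fold higher number from compound 1 to compound 2 (0.37 log units; beyond the scatter), both modest.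

The next compound is compound 4 `COc1ccc(CNc2cc(OC)c(OC)c(OC)c2)cc1F`, which carries fluoro in place of methoxycarbonyl on an aromatic carbon, ortho to a methoxy group: fluoro in place of methoxycarbonyl on an aromatic carbon. Among the compounds with values here, no fluoro compound has been measured yet, so the evidence is indirect. Within the data shown here, the closest precedent is the exchange of bromo, also a halogen, for methoxycarbonyl, which gave a 1.0-fold higher number from compound 2 to compound 3 (0.01 log units; within the scatter). Among the measured compounds shown here, the only steps beyond the scatter involve the nitro group, which takes no part in this change.

A change in this assay beyond the scatter is therefore not expected. The estimated step is a 1.1-fold lower number from compound 3 to compound 4 (0.06 log units; within the scatter). For compound 4 the estimated value is 36000 nM, with an expected range from 16000 nM to 80000 nM.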

Compound 4, half-maximal inhibitory concentration: 46200 nM
Compound 4: middle estimate off by 1.3-fold (0.11 log units), on the low side, and the stated range covers the measured number.
By their numbers in this assay, from the lowest: compound 1; then compounds 2, 3 and 4 (each within the scatter of the next).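

In this assay, fluoro, a single heavy atom with no hydrogen-bond acceptors, stands level with methoxycarbonyl, a group of 4 heavy atoms with 2 hydrogen-bond acceptors (a 1.1-fold higher number from compound 3 to compound 4 (0.05 log units; within the scatter)), and with bromo (a 1.2-fold higher number from compound 2 to compound 4 (0.06 log units; within the scatter)), so on this aromatic carbon, ortho to a methoxy group, compounds 2, 3 and 4 form one group despite that large difference in the size of the substituent. Nitro remains the only group set apart from the others, and compound 4 now adds a third step of the same kind (a 2.8-fold higher number from compound 1 to compound 4 (0.44 log units; beyond the scatter)), although that step is still modest. Nothing shown here explains why these three groups stand level or why nitro differs from them.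

The compounds shown leave open whether an amine or a carboxylic acid on this aromatic carbon would stand with compound 1 or with compounds 2, 3 and 4, and whether a longer chain there would keep the number level. They also leave open whether the same grouping would hold in any other cell line.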